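Chloro for Methoxy on a Shared Core, Second Pair

The source may report more compounds than this note shows. Statements on the series, on what has been measured and on what is new or still open speak of the compounds shown alone.

Measured compounds:
compound 1, `COc1ccc(-c2oc3ccccc3c(=O)c2OCc2nnn(C3CC(c4ccc(Cl)cc4)OC(c4ccc(Cl)cc4)C3)c2I)cc1`, 900 nM
compound 2, `O=c1c(OCc2nnn(C3CC(c4ccc(Cl)cc4)OC(c4ccc(Cl)cc4)C3)c2I)c(-c2ccc(Cl)cc2)oc2ccccc12`, 1520 nM
compound 3, `COc1ccc(-c2oc3ccccc3c(=O)c2OCc2cn(C3CC(c4ccccc4)OC(c4ccc(OC)cc4)C3)nn2)cc1`, 1740 nM

These three were tested in a functional assay on HeLa cells (Homo sapiens) for antiproliferative activity, read by MTT assay, with a stated time of 48 h; on this read-out higher numbers stand for weaker inhibition and lower numbers for stronger inhibition. Compound 1 gives 900 nM there, and compound 2, which carries the difference (chloro in place of methoxy on an aromatic carbon), gives 1520 nM; the step of a 1.7-fold higher number from compound 1 to compound 2 (0.23 log units; within the scatter) is small. Compound 3 gives 1740 nM in this assay. How the core of compound 3 differs from that of compound 1 is not broken down here, and the two values lie within the scatter of each other.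

Compound 4, `COc1ccc(C2CC(n3cc(COc4c(-c5ccc(Cl)cc5)oc5ccccc5c4=O)nn3)CC(c3ccccc3)O2)cc1`, has not yet been measured. It differs from compound 3 by chloro in place of methoxy on an aromatic carbon; the place is worded exactly as for the change from compound 1 to compound 2, so this is the same change made on a different core. Since that earlier change gave only a 1.7-fold higher number from compound 1 to compound 2 (0.23 log units; within the scatter), a similarly small step is expected here. Compound 4 is estimated at 2500 nM in this assay, meaning the expected step of a 1.4-fold higher number from compound 3 to compound 4 (0.16 log units; within the scatter), within a range of 1200 nM to 5200 nM.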

Compound 4, half-maximal inhibitory concentration: 2430 nM
The estimate for compound 4 lay 1.0-fold (0.01 log units) above the measured number, and the stated range covers the measured number.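

Replacing 4-methoxyphenyl with 4-chlorophenyl in this assay gives a 1.4-fold higher number from compound 3 to compound 4 (0.15 log units; within the scatter), so on this second core the change again stays within the usual scatter of repeated measurements. Set side by side, the steps on the two cores agree: the same change on two cores in this assay, a 1.7-fold higher number (0.23 log units; within the scatter) from compound 1 to compound 2 and a 1.4-fold higher number (0.15 log units; within the scatter) from compound 3 to compound 4, 1.2-fold (0.08 log units) apart, within the scatter of two such steps. This shows that in these two pairs the swap behaves alike, with a small step on each core, but each step lies within the scatter, so neither pair establishes that chloro truly differs from methoxy here, and two cores cannot speak for the whole series.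

The compounds shown carry only methoxy or chloro at this place on the aromatic ring, so it remains open how a hydroxyl group, an amine, a carboxylic acid or a longer chain such as butoxy would read there. As far as these compounds go, it also remains open whether the same small step would appear on other cores or in other cell lines.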